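A few compounds are considered here, and "the series" means these few. Any claim that something is new, unique, unknown or untested is made for them only; others in the source may bear on it.

Compound 3 `CCOC(=O)c1ccc(-c2cc3nccc(-c4cc(OC)c(OC)c(OC)c4)n3n2)cc1` is tested in a functional assay on A549 cells (Homo sapiens) for inhibition, read by CCK-8 assay, with a stated time of 48 h (a lower number here means a stronger inhibitor, a higher number a weaker inhibitor), where compound 3 reaches only the limit of the assay, > 10000 nM, the one limit among the three measurements (the limit of > 10000 nM in this assay, at which 1 of the 3 values shown sits). Two relatives give numbers: compound 1 `COc1cc(-c2ccnc3cc(-c4ccc(C(C)=O)cc4)nn23)cc(OC)c1OC` gives 4100 nM in this assay, and compound 2 `COc1cc(-c2ccnc3cc(-c4ccc(N(C)C)cc4)nn23)cc(OC)c1OC` gives 1100 nM. The steps that matter here are an at least 2.4-fold higher number from compound 1 to compound 3 (0.38 log units; beyond the scatter), by ethoxy in place of methyl on a carbonyl carbon, and an at least 9.0-fold higher number from compound 2 to compound 3 (0.95 log units; beyond the scatter); both end at compound 3, the weakest of the three. Compound 4 `C=Cc1ccc(-c2cc3nccc(-c4cc(OC)c(OC)c(OC)c4)n3n2)cc1` differs from compound 3 in one place: vinyl in place of ethoxycarbonyl on an aromatic carbon. Since the ethoxycarbonyl group marks the weak end of both measured steps, its removal is expected to bring a lower number, about an at least 2.8-fold lower number from compound 3 to compound 4 (0.45 log units; beyond the scatter). Compound 4 is therefore estimated at 3500 nM, with a range from 900 nM to 12000 nM.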

Compound 4, half-maximal inhibitory concentration: 1030 nM
Estimate against measurement, compound 4: 3.4-fold (0.53 log units) above; low and high end bracket the measured number.
By their numbers in this assay, from the lowest: compounds 4 and 2 (each within the scatter of the next); then compound 1. At a limit, above all of these: compound 3.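

Compound 3 stands at a limit, not a number: the limit of > 10000 nM in this assay, at which 1 of the 4 values shown sits. Even so, the change gives an at least 9.7-fold lower number from compound 3 to compound 4 (0.98 log units; beyond the scatter), while a group of carbon only proves as good as dimethylamino, with a 1.1-fold lower number from compound 2 to compound 4 (0.03 log units; within the scatter), and better than acetyl, with a 4.0-fold lower number from compound 1 to compound 4 (0.60 log units; beyond the scatter). At this place, then, both carbonyl-bearing groups shown, acetyl and ethoxycarbonyl, fall behind vinyl, and a nitrogen is not needed to match dimethylamino.

As far as these compounds go, what an ethyl group, a primary amine or a carboxylic acid would give at this place stays open. The reason for these differences also stays open.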